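This account rests on a few compounds, and the source may have more. Where it says the series, first, only, none or still open, it means among the compounds named here.

Measured compounds:
compound 1 `O=C(Nc1ccc(Oc2ccnc3[nH]ccc23)cc1)c1nccc(-c2ccc(F)cc2)n1` — in a functional assay on MCF7 cells (Homo sapiens) for cytotoxicity, read by MTT assay, with a stated time of 72 h (on this read-out lower numbers stand for stronger inhibition and higher numbers for weaker inhibition), compound 1 gives "not active" (no number reported)
compound 2 `COc1ccc(-c2cc(C(=O)Nc3ccc(Oc4ccnc5[nH]ccc45)cc3)ncn2)cc1` — in this assay compound 2 gives 4450 nM

Compound 2 holds the only number shown in this assay; the further entry, compound 1, is reported without a single number, so no step between measured compounds can be drawn, and nothing about the size of a change within this series is known from measurement. Compound 3 `O=C(Nc1ccc(Oc2ccnc3[nH]ccc23)cc1)c1cc(-c2ccc(Cl)cc2)ncn1` is not yet measured. It differs from compound 2 in one place: chloro in place of methoxy on an aromatic carbon. Among the compounds with values here, with no measured step to lean on, the expectation for compound 3 can only be cautious: a step of modest size, slightly toward weaker inhibition, and possibly none beyond the scatter, is expected, written as a 1.3-fold higher number from compound 2 to compound 3 (0.13 log units; within the scatter). Compound 3 is therefore estimated at 6000 nM in this assay, within a range from 2000 nM to 20000 nM.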

Compound 3, half-maximal inhibitory concentration: 7770 nM
The estimate for compound 3 lay 1.3-fold (0.11 log units) below the measured number; low and high end bracket the measured number.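

In this assay, within the data shown here, chloro in place of methoxy on the aromatic carbon para to a large group gives a 1.7-fold higher number from compound 2 to compound 3 (0.24 log units; within the scatter) and so provides the first measured step. At this position, the 4-methoxyphenyl and 4-chlorophenyl forms cannot be told apart on this read-out, even though the change swaps two heavy atoms, one of them a hydrogen-bond acceptor, for a single chlorine atom that is not an acceptor. Nothing at hand explains this result.

As far as these compounds go, whether an amine, a carboxylic acid or a longer alkoxy chain at this position would move the number beyond the scatter remains open. Also open, from the compounds shown here alone, is how far a change elsewhere on the shared core would shift the number, since this one step bears on a single position.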